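The source may report more compounds than this note shows. Statements on the series, on what has been measured and on what is new or still open speak of the compounds shown alone.

Working notes on solubility in a physicochemical assay for solubility, read by LC-MS, measured as thermodynamic solubility, at pH 6.8; on this read-out lower numbers stand for lower solubility and higher numbers for higher solubility. Compound 1 `CCC(=O)N1CC[C@H](Oc2ncnc3c2CN(c2ccc(OC)nc2)CC3)C1` returns only a limit of this assay, > 1000000 nM. Compound 2 `COc1ncc(N2CCc3ncnc(O[C@H]4CCN(C(=O)C5CCOCC5)C4)c3C2)cc1C` likewise returns a limit, > 1000000 nM. Going by the values given here, compound 3 `COc1ccc(N2CCc3ncnc(-c4cccc(OC5CCN(C(C)=O)CC5)c4)c3C2)cn1` also comes back at a limit, > 1000000 nM. the limit of > 1000000 nM in this assay, at which 3 of the 3 values shown sit — so the set holds no numbered value and no measured step, and compound 3 cannot be placed relative to compound 1 or compound 2 other than by noting that all three sit at the same limit.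

Compound 4 `COc1ccc(N2CCc3ncnc(-c4cccc(C(=O)N5CCN(C(C)=O)CC5)c4)c3C2)cn1` is the next member to go into this assay. ((4-acetylpiperazin-1-yl)carbonyl in place of (1-acetylpiperidin-4-yl)oxy on an aromatic carbon). Among the compounds with values here, no measured step is available to guide the size of the change; the working expectation is that the step from compound 3 to compound 4 stays within the scatter of this assay, with no direction claimed, and that compound 4 most likely comes back at a limit again rather than as a number. The expected step is an at least 1.2-fold lower number from compound 3 to compound 4 (0.09 log units; that floor lies within the scatter). Compound 4 is accordingly expected to give 800000 nM, with a range from 200000 nM to 1000000 nM.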

Compound 4, solubility: > 1000000 nM
Compound 4: only a limit was reported; the forecaster's own chance of this, stated with the estimate: 70%; middle value at least 1.2-fold (0.09 log units) from the limit.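

Compound 4 also returns only a limit in this assay, as does compound 3, so no step between the two can be read: the limit of > 1000000 nM in this assay, at which 4 of the 4 values shown sit.

The compounds shown leave open where any of them would fall as a number, and whether (4-acetylpiperazin-1-yl)carbonyl in place of (1-acetylpiperidin-4-yl)oxy shifts the read-out at all.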